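Thiazoline to oxazoline swap on a pyrazoline sulfone

The source may hold more compounds than are shown below. What is called first, only, known or untested is meant among the compounds shown, and "the series" means these compounds.

Compound 1, `O=S(=O)(CC1=NCCS1)C1C(c2ccccc2)=NN(c2ccccc2)C1c1ccccc1`, is the starting point. In a functional assay, tested at 100 ug/mL (a higher number here means a stronger effect of the compound at the concentration tested, a lower number a weaker effect), compound 1 is recorded as "not active" (no number reported), so no number stands against it. Compound 3, `O=S(=O)(CC1=NCCS1)c1c(-c2ccccc2)nn(-c2ccccc2)c1-c1ccccc1`, carries the same thiazoline sulfone arm on an aromatic core and in this assay compound 3 is likewise "not active" (no number reported). Going by the values given here, compound 2, `COc1ccc(C2=NOC(c3ccc(C)cc3)C2S(=O)(=O)CC2=NCCO2)cc1`, is the only member of the series with a reported figure: in this assay compound 2 gives 70.9%. Compound 2 differs from compound 1 in more than one place, so its value cannot be read as a single step.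

Compound 4, `O=S(=O)(CC1=NCCO1)C1C(c2ccccc2)=NN(c2ccccc2)C1c1ccccc1`, is not yet measured. It differs from compound 1 by a group of 5 heavy atoms (3 carbon, 1 nitrogen, 1 oxygen; one five-membered non-aromatic ring with 2 hetero atoms) in place of a group of 5 heavy atoms (3 carbon, 1 nitrogen, 1 sulfur; one five-membered non-aromatic ring with 2 hetero atoms), on a saturated chain carbon bound to a sulfonyl sulfur. Among the compounds with values here, the oxazoline arm is the arm found on compound 2, the one compound with a measurable effect, while both thiazoline compounds, compound 1 and compound 3, are without activity. Within the data shown here, no measured pair isolates this change, so the direction rests on that contrast alone: some gain over compound 1 is expected, of uncertain size, with a real chance that compound 4 again shows no activity. In this assay compound 4 is expected to give about 25%, within 0% to 60%.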

Compound 4, a percentage reported as activity, at one concentration (the size of the read-out at that concentration, not a potency): 48.1%
For compound 4 the middle estimate is 23.1 percentage points below the measured one; low and high end bracket the measured number.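

No step can be read from compound 1 to compound 4: in this assay compound 4 gives 48.1% while compound 1 carries no number. No evidence on a cause is at hand. The compounds shown leave open how large the effect of exchanging the thiazoline arm for the oxazoline arm is on any shared core.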